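Methoxy for Nitrile on the Benzyl Arm

A few compounds are considered here, and "the series" means these few. Any claim that something is new, unique, unknown or untested is made for them only; others in the source may bear on it.

In an in vitro functional assay on cells for agonist activity at Bombesin receptor subtype-3 (Homo sapiens), read by luminescence and calcium flux (a lower number here means that less compound is needed, a higher number that more compound is needed for the effect), compound 1 `O=C(O)c1ccccc1-c1ccc(CCc2ncc(Cc3ccccc3Cl)[nH]2)cc1` gives 292 nM, compound 2 `N#Cc1ccc(Cc2cnc(CCc3ccc(-c4ccccc4C(=O)O)cc3)[nH]2)cc1` gives 5890 nM, and compound 3 `N#Cc1cccc(Cc2cnc(CCc3ccc(-c4ccccc4C(=O)O)cc3)[nH]2)c1` gives 812 nM, placing compound 3 second highest of the three. The steps are a 2.8-fold higher number from compound 1 to compound 3 (0.44 log units; beyond the scatter) and a 7.3-fold lower number from compound 2 to compound 3 (0.86 log units; beyond the scatter). Compound 4 `COc1ccccc1Cc1cnc(CCc2ccc(-c3ccccc3C(=O)O)cc2)[nH]1` differs from compound 3 by 2-methoxyphenyl in place of 3-cyanophenyl on a saturated chain carbon bound to an aromatic carbon. Among the measured compounds shown here, no measured step swaps a nitrile for a methoxy group, so the bearing steps are only those above; the lowest number so far belongs to compound 1 with its 2-chlorophenyl. The step is expected to be a 2.0-fold lower number from compound 3 to compound 4 (0.31 log units; beyond the scatter), a modest lowering. In this assay compound 4 is therefore estimated at 400 nM, between 150 nM and 1200 nM.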

Compound 4, half-maximal effective concentration: 1720 nM
For compound 4 the middle estimate is 4.3-fold (0.63 log units) below the measured one; the whole stated range lies below it.
By their numbers in this assay, from the lowest: compound 1; then compound 3; then compound 4; then compound 2.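

Swapping in 2-methoxyphenyl gives a 2.1-fold higher number from compound 3 to compound 4 (0.33 log units; beyond the scatter) in this assay, whereas the same group gives a 3.4-fold lower number from compound 2 to compound 4 (0.53 log units; beyond the scatter) when set against 4-cyanophenyl, so compound 4 falls within the span of the two nitriles. With the substituent kept at the same ring position, methoxy in place of chloro gives a 5.9-fold higher number from compound 1 to compound 4 (0.77 log units; beyond the scatter) and shows that the choice of group there matters. Nothing shown here explains these differences. On these data alone, whether 3-methoxyphenyl would differ from 2-methoxyphenyl remains open, as does how 2-fluorophenyl or unsubstituted phenyl would compare with compound 1.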